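The compounds below may be only part of what the source reports. "The series", "measured", "known", "first", "only" and "open" are said of these compounds alone.

Values in an in vitro ADME assay on microsomes from Gut (Homo sapiens) for metabolic stability, using NADPH; a higher number here means faster removal of the compound, a lower number slower removal; each is a limit of the assay, not a number:

- Compound 1 `COc1ccc(OC(F)(F)F)cc1Cn1c(C(=O)NCC(C)(C)O)cc2cc(C#N)ccc21`: < 6 mL.min-1.g-1
- Compound 2 `CC(C)(O)CCNC(=O)c1cc2cc(C#N)ccc2n1Cc1cccc(OC(F)(F)F)c1`: < 6 mL.min-1.g-1
- Compound 3 `CC(O)CCNC(=O)c1cc2cc(C#N)ccc2n1Cc1cccc(OC(F)(F)F)c1`: < 6 mL.min-1.g-1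

Compound 3 therefore has no exact position, and neither do the other two: the limit of < 6 mL.min-1.g-1 in this assay, at which 3 of the 3 values shown sit. Compound 4 `N#Cc1ccc2c(c1)cc(C(=O)NCCC(O)(C(F)(F)F)C(F)(F)F)n2Cc1cccc(OC(F)(F)F)c1` has 2,2,2-trifluoro-1-hydroxy-1-(trifluoromethyl)ethyl in place of 1-hydroxyethyl on a saturated chain carbon, two bonds along the chain from an amide-type nitrogen. Among the compounds with values here, the only measured step on this part of the chain is a step that the two limits leave unreadable from compound 2 to compound 3, so it offers no size to carry over. With so little to go on, the expected step that the limit leaves unreadable from compound 3 to compound 4 is none beyond the scatter, in either direction. Compound 4 is estimated at 5 mL.min-1.g-1, with an expected range of 3 mL.min-1.g-1 to 12 mL.min-1.g-1.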

Compound 4, intrinsic clearance in microsomes: < 6 mL.min-1.g-1
Compound 4 gave a limit, no number; the forecaster's own chance of this, stated with the estimate: 70%; the middle value lies beyond the limit too.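

No step to compound 4 from compound 2 or compound 3 can be read, as each gives only a limit: the limit of < 6 mL.min-1.g-1 in this assay, at which 4 of the 4 values shown sit.

In this assay, as far as these compounds go, the actual removal rates of all four compounds stay open, and so does whether replacing 1-hydroxyethyl with 2,2,2-trifluoro-1-hydroxy-1-(trifluoromethyl)ethyl changes anything.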